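A few compounds are considered here, and "the series" means these few. Any claim that something is new, unique, unknown or untested is made for them only; others in the source may bear on it.

Working notes on the series, read in a functional assay on HCT-116 cells (Homo sapiens) for antiproliferative activity, read by MTT assay, with a stated time of 48 h; on this read-out lower numbers stand for stronger inhibition and higher numbers for weaker inhibition. Compound 1 `COc1ccc(-n2nncc2CN2C(=O)C3(C(C#N)=C(N)Oc4c3c3nc5ccccc5nc3c3ccccc43)c3ccccc32)cc1` returns only a limit of the assay in this assay, > 50000 nM. Compound 2 `N#CC1=C(N)Oc2c(c3nc4ccccc4nc3c3ccccc23)C12C(=O)N(Cc1cnnn1-c1ccc(N)cc1)c1ccccc12` gives 45200 nM in this assay, so the step of an at least 1.1-fold lower number from compound 1 to compound 2 (0.04 log units; that floor lies within the scatter) is bounded by the limit of > 50000 nM in this assay, at which 1 of the 3 values shown sits, and cannot be sized further. Compound 3 `N#CC1=C(N)Oc2c(N)cc3nc4ccccc4nc3c2C12C(=O)N(Cc1cnnn1-c1cccc(Br)c1)c1ccccc12` gives 26100 nM in this assay, the lowest of the two numbers shown; compound 2 lies within the scatter of it, so no order between the two is claimed. Among the measured compounds shown here, compound 3 differs from compound 2 in more than one place, and no single step is drawn between them.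

Compound 4 `N#CC1=C(N)Oc2c(N)cc3nc4ccccc4nc3c2C12C(=O)N(Cc1cnnn1-c1c(F)cccc1F)c1ccccc12` is not yet measured. It differs from compound 3 by 2,6-difluorophenyl in place of 3-bromophenyl on an aromatic nitrogen. For the measured compounds named here, the only measured step in the set, amino in place of methoxy on an aromatic carbon, touches another part of the shared core, and no measured step bears on an exchange of the group on the aromatic nitrogen. Going by the values given here, the weak activity of the whole set leaves little room for a drop in the number, and the change carries no precedent here. Compound 4 is therefore expected to stay close to compound 3, with a 1.1-fold higher number from compound 3 to compound 4 (0.06 log units; within the scatter) not beyond the scatter. Compound 4 is estimated at 30000 nM in this assay, in the range 12000 nM to 60000 nM.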

Compound 4, half-maximal inhibitory concentration: > 50000 nM
Compound 4: no number, only a limit; the forecaster's own chance of this, stated with the estimate: 25%; middle value at least 1.6-fold (0.22 log units) from the limit.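

Among the compounds shown here, the exchange on the aromatic nitrogen of the five-membered aromatic ring is the first step in the set that reads this position, and in this assay it gives an at least 1.9-fold higher number from compound 3 to compound 4 (0.28 log units; that floor lies within the scatter). On these data alone, that figure is only a floor on the step, so a real difference between 3-bromophenyl and 2,6-difluorophenyl at this position is possible but not established, and the true size of the step stays unknown. The pair shows no gain from 2,6-difluorophenyl, and compound 4 now sits with compound 1 at the assay limit, where further differences cannot be sized: the limit of > 50000 nM in this assay, at which 2 of the 4 values shown sit.

The pair replaces the bromine and brings in both fluorines in one exchange, so the compounds shown do not separate the loss of the one from the arrival of the other; 3-fluorophenyl or unsubstituted phenyl on the same nitrogen would bear on that. Also open, as far as these compounds go, is whether any group at this position, such as a phenyl ring carrying a carboxylic acid or an amine on a longer chain, brings the number clearly below that of compound 3.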